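Amide cap change in a weakly active series

The source may report more compounds than this note shows. Statements on the series, on what has been measured and on what is new or still open speak of the compounds shown alone.

Compound 1 `CCN(CC)S(=O)(=O)c1ccc(S(=O)(=O)N2CCC[C@@H](C(=O)NC3CN(C(=O)OC(C)(C)C)C3)C2)cc1` carries a 1-(tert-butoxycarbonyl)azetidin-3-yl group on its amide nitrogen. In a functional assay on MIA PaCa-2 cells (Homo sapiens) for inhibition, read by MTT assay, with a stated time of 3 days (a higher number here means a weaker inhibitor, a lower number a stronger inhibitor), compound 1 gives > 10000 nM, which is a limit of the assay and not a number. Two related esters sit the same way. Compound 2 `CCOC(=O)[C@@H]1CCCN(S(=N)(=O)c2ccc(S(=O)(=O)N(CC)CC)cc2)C1` gives > 10000 nM in this assay, again a limit rather than a number. Compound 3 `CCOC(=O)[C@@H]1CCCN(S(=O)(=O)c2ccc(S(=N)(=O)N(CC)CC)cc2)C1` gives > 10000 nM in this assay, also a limit. Compound 1 therefore stands level with everything else shown: the limit of > 10000 nM in this assay, at which 3 of the 3 values shown sit, and no measured step between two compounds exists to set a scale for the series.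

Compound 4 `CCN(CC)S(=O)(=O)c1ccc(S(=O)(=O)N2CCC[C@@H](C(=O)NC3COC3)C2)cc1` is the unmeasured partner. The change from compound 1 to compound 4 is oxetan-3-yl in place of 1-(tert-butoxycarbonyl)azetidin-3-yl on an amide-type nitrogen. With all three values resting at the limit, the step in this assay from compound 1 to compound 4 cannot be anchored to any measured movement; the expectation is that no change beyond the scatter appears and that compound 4 also reports a limit. The estimated step that the limit leaves unreadable from compound 1 to compound 4 is expected to be flat. Compound 4 is estimated at 15000 nM, within 5000 nM to 50000 nM, in this assay.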

Compound 4, half-maximal inhibitory concentration: > 10000 nM
Compound 4: no number, only a limit (the forecaster's own chance of this, stated with the estimate: 85%); the middle value does not contradict the limit.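

For the compounds shown here, compound 1 and compound 4 both rest at a limit and not at a number, so no step between them can be read in this assay. The series stands at a single reading: the limit of > 10000 nM in this assay, at which 4 of the 4 values shown sit.

The compounds shown leave open whether any change to the shared core gives a measurable value in this assay.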